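Chloro to Fluoro on the Fused Benzenoid Ring

This account rests on a few compounds, and the source may have more. Where it says the series, first, only, none or still open, it means among the compounds named here.

The shared core of this small set is seen in compound 1 `Brc1cccc2c1nnn2CC1CC1`, which in an ADME assay on microsomes from liver (Homo sapiens) for metabolic stability, tested at 2.5 uM (on this read-out lower numbers stand for slow clearance and higher numbers for fast clearance), gives 1.3 mL/min/g. Compound 2 `Clc1cc(Br)c2nnn(CC3CC3)c2c1` carries a chloro group on the six-membered ring and in this assay gives 0.5 mL/min/g. Going by the values given here, the one measured step, a 2.6-fold lower number from compound 1 to compound 2 (0.41 log units; beyond the scatter), comes from chloro in place of hydrogen on an aromatic carbon. Among the two numbers in hand, compound 2 stands lowest, with compound 1 as its only neighbour.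

Compound 3 `Fc1cc(Br)c2nnn(CC3CC3)c2c1` differs from compound 2 by fluoro in place of chloro on an aromatic carbon. Among the compounds with values here, no measured pair shows fluoro in place of chloro, so the only bearing comes from the step from compound 1 to compound 2, which shows what adding chloro did. Fluoro may not carry the whole of that change, so compound 3 is expected to sit between compound 1 and compound 2, the step of a 1.6-fold higher number from compound 2 to compound 3 (0.20 log units; within the scatter) expected to stay within the scatter. The estimate for compound 3 in this assay is 0.8 mL/min/g, in a range from 0.4 mL/min/g to 1.6 mL/min/g.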

Compound 3, intrinsic clearance in a liver preparation (reported as CLH), per the amount of preparation that the assay uses: 0.4 mL/min/g
Beside the measured number, compound 3's estimate is 2.0-fold (0.30 log units) above it; the measured number falls inside the stated range.
By their numbers in this assay, from the lowest: compounds 3 and 2 (each within the scatter of the next); then compound 1.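

In this assay, fluoro in place of chloro on this aromatic carbon, para to a fused ring and meta to a bromo group, gives a 1.3-fold lower number from compound 2 to compound 3 (0.10 log units; within the scatter) and leaves the two halogens indistinguishable at this position. Fluoro in place of hydrogen on the same carbon gives a 3.3-fold lower number from compound 1 to compound 3 (0.51 log units; beyond the scatter) and shows that the earlier drop seen with chloro is not peculiar to chloro: both halogens at this place read lower than hydrogen, with no compound among the three going against that. No measurement at hand explains why the read-out moves with either halogen.

The compounds shown leave open whether a halogen is needed at all, as a methyl group, a methoxy group, a nitrile or an amine on this carbon would give a reading of a different kind of substituent. They also leave open whether the same drop would hold if the bromo group were replaced, for example by a carboxylic acid or a longer chain.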